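This account rests on a few compounds, and the source may have more. Where it says the series, first, only, none or still open, it means among the compounds named here.

Within the data shown here, compound 3 `O=C1c2c[n+]([O-])c3ccccc3c2C(=O)c2c1c1ccccc1n2Cc1cn(CC(O)CO)nn1` stands at the highest of the three numbers measured so far in a functional assay on HCT-116 cells (Homo sapiens) for cytotoxicity, read by MTT assay, with a stated time of 72 h (a higher number here means a weaker inhibitor, a lower number a stronger inhibitor), where compound 3 gives 250 nM. Compound 2 `O=C1c2c[n+]([O-])c3ccccc3c2C(=O)c2c1c1ccccc1n2Cc1cn(C[C@@H](O)CO)nn1` gives 190 nM, and compound 1 `O=C1c2c[n+]([O-])c3ccccc3c2C(=O)c2c1c1ccccc1n2Cc1cn([C@H]2C[C@H](O)[C@@H](CO)O2)nn1` gives 120 nM. The step of a 2.1-fold higher number from compound 1 to compound 3 (0.32 log units; beyond the scatter) and the step of a 1.6-fold higher number from compound 1 to compound 2 (0.20 log units; within the scatter) both describe a 2,3-dihydroxypropyl replacing the 4-hydroxy-5-(hydroxymethyl)oxolan-2-yl, and the number rose in each case, modestly at most. Compound 4 `O=C1c2c[n+]([O-])c3ccccc3c2C(=O)c2c1c1ccccc1n2Cc1cn([C@H]2O[C@H](CO)[C@@H](O)[C@H]2O)nn1` makes a change of the opposite kind: 3,4-dihydroxy-5-(hydroxymethyl)oxolan-2-yl in place of 2,3-dihydroxypropyl on an aromatic nitrogen. Those two measured steps run the other way, so for compound 4 a modest fall in the number is expected, a 1.9-fold lower number from compound 3 to compound 4 (0.28 log units; within the scatter). The estimate for compound 4 in this assay is 130 nM, with a range from 60 nM to 300 nM.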

Compound 4, half-maximal inhibitory concentration: 710 nM
Beside the measured number, compound 4's estimate is 5.5-fold (0.74 log units) below it, and the stated range ends below it.
By their numbers in this assay, from the lowest: compounds 1, 2 and 3 (each within the scatter of the next, the first and the last beyond it); then compound 4.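

In this assay, placing 3,4-dihydroxy-5-(hydroxymethyl)oxolan-2-yl on this aromatic nitrogen in place of 2,3-dihydroxypropyl gives a 2.8-fold higher number from compound 3 to compound 4 (0.45 log units; beyond the scatter) and a 3.7-fold higher number from compound 2 to compound 4 (0.57 log units; beyond the scatter) on the same change. The gap is wider between the two oxolan-2-yl groups, with a 5.9-fold higher number from compound 1 to compound 4 (0.77 log units; beyond the scatter) for the group carrying the extra ring hydroxyl. An oxolane ring at this place therefore does not by itself keep the number low, since compound 1 and compound 4 stand at opposite ends of the order. The compounds shown leave open whether that extra hydroxyl or its configuration accounts for the rise, and how an amine in its place would read. The drawn configuration of compounds 2 and 3 does not bear on this result.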